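Removing an acetyl group: two steps in one series

The source may report more compounds than this note shows. Statements on the series, on what has been measured and on what is new or still open speak of the compounds shown alone.

Measured compounds:
compound 1, `C=C1CC[C@@H]2[C@](C)(COC(C)=O)[C@H](OC(C)=O)CC[C@@]2(C)[C@@H]1C/C=C1/C(=O)OC[C@H]1OC(C)=O`, gives 12.4 uM in a functional assay on Lu1 cells (Homo sapiens) for cytotoxicity, read by sulforhodamine B assay; a lower number here means that less compound is needed, a higher number that more compound is needed for the effect
compound 2, `C=C1CC[C@@H]2[C@](C)(CO[Si](c3ccccc3)(c3ccccc3)C(C)(C)C)[C@H](OC(C)=O)CC[C@@]2(C)[C@@H]1C/C=C1/C(=O)OC[C@H]1O`, gives 10.9 uM in this assay
compound 3, `C=C1CC[C@@H]2[C@](C)(CO)[C@H](OC(C)=O)CC[C@@]2(C)[C@@H]1C/C=C1/C(=O)OC[C@H]1OC(C)=O`, gives 8.75 uM in this assay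

The three measured values lie close together. Compound 1 and compound 3 differ in one place only, (hydrogen in place of acetyl on an oxygen on a saturated carbon), and that change made a step of a 1.4-fold lower number from compound 1 to compound 3 (0.15 log units; within the scatter) in this assay. Compound 2 stands apart from compound 1 in more than one place; the difference between the two cores is not broken down here, and the values of compound 1 and compound 2 are within the scatter of each other.

Compound 4, `C=C1CC[C@@H]2[C@](C)(CO[Si](c3ccccc3)(c3ccccc3)C(C)(C)C)[C@H](O)CC[C@@]2(C)[C@@H]1C/C=C1/C(=O)OC[C@H]1O`, is not yet measured. It arises from compound 2 by hydrogen in place of acetyl on an oxygen on a saturated carbon. Among the compounds with values here, this is the same kind of change as the one from compound 1 to compound 3, not the same change: there the oxygen sits on a saturated carbon whose other neighbour is a saturated chain carbon, here the saturated carbon's other neighbour is a saturated ring carbon. Within the data shown here, with only one measured example of this change, the expectation for compound 4 rests on that one step. Because a 1.4-fold lower number from compound 1 to compound 3 (0.15 log units; within the scatter) lay within the scatter, a step of similar size, a 1.3-fold lower number from compound 2 to compound 4 (0.11 log units; within the scatter), is expected from compound 2 to compound 4 in this assay. Compound 4 is therefore estimated at 8.5 uM, with a range of 4 uM to 18 uM reflecting the wider uncertainty of transferring a step between two different cores.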

Compound 4, concentration for half-maximal effect: 11.5 uM
Compound 4: middle estimate off by 1.4-fold (0.13 log units), on the low side; the range from low to high includes it.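

In this assay, replacing acetyl with hydrogen on an oxygen on a saturated carbon whose other neighbour is a saturated ring carbon made a step of a 1.1-fold higher number from compound 2 to compound 4 (0.02 log units; within the scatter). Set beside the earlier step of the same kind, the result gives no sign that the two cores respond differently: the same change on two cores in this assay, a 1.4-fold lower number (0.15 log units; within the scatter) from compound 1 to compound 3 and a 1.1-fold higher number (0.02 log units; within the scatter) from compound 2 to compound 4, 1.5-fold (0.17 log units) apart, within the scatter of two such steps. Within the data shown here, this shows only that the change produced no step beyond the scatter in either of these two pairs; it does not show that the change is without effect on other cores, and it cannot separate the role of the core from that of the oxygen's place, since the two pairs differ in both.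

The compounds shown replace acetyl only with hydrogen, so a longer acyl chain, a methyl ether, a carbamate or an amine in the same place remains open, as does whether any of these would give a step beyond the scatter. Among these compounds, with only two pairs, both read in a single cell assay, it also remains open whether the same result would hold on a third core or in a different assay.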